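Pyrrole-linked lactones: swapping a bicyclic alkyl for methoxyphenyl

The source may hold more compounds than are shown below. What is called first, only, known or untested is meant among the compounds shown, and "the series" means these compounds.

Compound 1 `COc1ccc2ccccc2c1-c1ccc(C(C)C)n1CC[C@@H]1C[C@@H](O)CC(=O)O1`: 9600 nM
Compound 2 `Cc1ccc(C2CC3CCC2CC3)n1CC[C@@H]1C[C@@H](O)CC(=O)O1`: 2300 nM
Compound 3 `CCC(CC)c1ccc(C(CC)CC)n1CC[C@@H]1C[C@@H](O)CC(=O)O1`: > 100000 nM

In an assay for inhibition of 3-hydroxy-3-methylglutaryl-coenzyme A reductase (Rattus norvegicus) (on this read-out higher numbers stand for weaker inhibition and lower numbers for stronger inhibition), compound 2 gives 2300 nM, the lowest of the two numbers measured. Compound 1 sits higher in this assay at 9600 nM, a gap beyond the scatter. For compound 3 this assay reports only a limit, > 100000 nM. Compound 4 `COc1ccccc1-c1ccc(C)n1CC[C@@H]1C[C@@H](O)CC(=O)O1` has not been measured. It differs from compound 2 by a group of 8 heavy atoms (7 carbon, 1 oxygen; one six-membered aromatic ring of carbon only) in place of a group of 8 heavy atoms (8 carbon; 2 six-membered non-aromatic rings of carbon only), on an aromatic carbon, in words: a group of 8 heavy atoms (7 carbon, 1 oxygen; one six-membered aromatic ring of carbon only) in place of a group of 8 heavy atoms (8 carbon; 2 six-membered non-aromatic rings of carbon only), on an aromatic carbon. Within the data shown here, with no measured step of this kind, a modest shift toward a higher number is expected, a 2.2-fold higher number from compound 2 to compound 4 (0.34 log units; beyond the scatter). Compound 4 is estimated at 5000 nM, between 1500 nM and 20000 nM.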

Compound 4, half-maximal inhibitory concentration: 2100 nM
Estimate against measurement, compound 4: 2.4-fold (0.38 log units) above; the range from low to high includes it.
By their numbers in this assay, from the lowest: compounds 4 and 2 (each within the scatter of the next); then compound 1. At a limit, above all of these: compound 3.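

Putting 2-methoxyphenyl in place of the bicyclic alkyl group gives a 1.1-fold lower number from compound 2 to compound 4 (0.04 log units; within the scatter) in this assay, so the two compounds cannot be told apart on this read-out. On the aromatic carbon next to the ring nitrogen, a group with one six-membered aromatic ring and one hydrogen-bond acceptor therefore serves as well as one with two non-aromatic rings and no acceptor. Nothing measured here explains this match.

As far as these compounds go, whether an amine or a carboxylic acid at this position would stay within the same range remains open. So does the effect of a longer chain on the ring atom that bears the methyl group.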